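This account rests on a few compounds, and the source may have more. Where it says the series, first, only, none or still open, it means among the compounds named here.

In a functional assay on Huh7.5.1 cells (Homo sapiens) for cytotoxicity, read by MTT assay, with a stated time of 72 h (on this read-out lower numbers stand for higher toxicity in this test and higher numbers for lower toxicity in this test), compound 1 `C=c1[nH]c(=O)/c(=C/c2ccccc2)[nH]c1=O` gives only a limit of the assay, > 20000 nM. Compound 2 `C=c1[nH]c(=O)/c(=C/c2ccc(OC)cc2)[nH]c1=O` also gives only a limit, > 20000 nM. Compound 2 thus stands at the limit of > 20000 nM in this assay, at which 2 of the 2 values shown sit, with no number to fix its place. Compound 3 `C=c1[nH]c(=O)/c(=C/c2ccc(OC)c(OC)c2)[nH]c1=O` differs from compound 2 by a single change, methoxy in place of hydrogen on an aromatic carbon, ortho to a methoxy group. Going by the values given here, the one measured step of the same kind is a step that the two limits leave unreadable from compound 1 to compound 2. That step offers no size to carry over, so nothing beyond the usual scatter is expected in this assay, and no direction can be argued. The estimated step is a number no higher from compound 2 to compound 3 (the limit leaves the size open). Compound 3 is expected at about 20000 nM, with an estimated range from 10000 nM to 40000 nM, and most likely the assay will again report only a limit.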

Compound 3, half-maximal cytotoxic concentration: > 20000 nM
Compound 3 ended at the assay's limit (the forecaster's own chance of this, stated with the estimate: 85%); the middle value sits exactly at the limit.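

No size can be read for the change from compound 2 to compound 3, since both sit at a limit in this assay: the limit of > 20000 nM in this assay, at which 3 of the 3 values shown sit. The compounds shown leave open where their actual cytotoxic concentrations lie and whether adding either methoxy group changes them at all.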